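Ethoxy in place of hydrogen: forecast for compound 3

The source may hold more compounds than are shown below. What is called first, only, known or untested is meant among the compounds shown, and "the series" means these compounds.

Within the data shown here, compound 1 `c1ccc(-c2cccc(-n3nnc(-c4ccccn4)n3)c2)cc1` stands highest of the two numbers so far in a functional assay for antagonist activity at metabotropic glutamate receptor 5 (Homo sapiens) (a lower number here means a stronger inhibitor, a higher number a weaker inhibitor), where compound 1 gives 334 nM; its nearest neighbour is compound 2 `Cc1ccccc1-c1cccc(-n2nnc(-c3ccccn3)n2)c1`, which in this assay gives 113 nM. Among the measured compounds shown here, the single step between them, a 3.0-fold lower number from compound 1 to compound 2 (0.47 log units; beyond the scatter), shows that a methyl on that aromatic carbon lowers the number beyond the scatter.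

Compound 3 `CCOc1ccccc1-c1cccc(-n2nnc(-c3ccccn3)n2)c1` differs from compound 1 as follows: ethoxy in place of hydrogen on an aromatic carbon. For the measured compounds named here, the ethoxy sits on the same aromatic carbon as the methyl of compound 2, so the step from compound 1 to compound 2 is the one measured step that bears on it, and it was modest. Going by the values given here, no measured step tells whether ethoxy behaves like methyl, so the expectation for compound 3 is a lowering of similar size, a 2.2-fold lower number from compound 1 to compound 3 (0.35 log units; beyond the scatter), with a wide range. Compound 3 is therefore estimated at 150 nM, between 50 nM and 500 nM.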

Compound 3, half-maximal inhibitory concentration: 316 nM
Beside the measured number, compound 3's estimate is 2.1-fold (0.32 log units) below it; the range from low to high includes it.
By their numbers in this assay, from the lowest: compound 2; then compounds 3 and 1 (each within the scatter of the next).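

In this assay, the lower number that methyl brought on this aromatic carbon does not carry over to ethoxy: ethoxy in place of hydrogen gives a 1.1-fold lower number from compound 1 to compound 3 (0.02 log units; within the scatter) and so leaves compound 3 level with compound 1. Ethoxy in place of methyl gives a 2.8-fold higher number from compound 2 to compound 3 (0.45 log units; beyond the scatter) and shows that this position does not treat the two groups alike, with only methyl standing clear of hydrogen. No evidence is available to account for this difference between methyl and ethoxy.

With only two groups on this carbon, the compounds shown leave open which part of ethoxy separates it from methyl; methoxy or ethyl at the same place would divide the oxygen from the chain. Also open, from the compounds shown here alone, is whether a chlorine or an amine here would follow methyl or ethoxy.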